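The source may report more compounds than this note shows. Statements on the series, on what has been measured and on what is new or still open speak of the compounds shown alone.

Measured compounds:
- compound 1, `CN(C)CCCNc1nc(NCc2ccco2)c2ccccc2n1`: in a functional assay on HT-29 cells (Homo sapiens) for cytotoxicity, read by MTT assay, with a stated time of 2 days, tested at 10 uM (a lower number here means less inhibition, a higher number more inhibition at the concentration tested (going by the name of the read-out)), compound 1 gives "not determined" (no result reported)
- compound 2, `CCN(CC)CCNc1nc(NCc2ccco2)c2cc(F)ccc2n1`: in this assay compound 2 gives 27.5%

Among the measured compounds shown here, only two compounds have been put through this assay, and only one of them has a number. For the measured compounds named here, compound 1 was tested but no result was reported, so compound 2, with its single value, stands alone: there is nothing to rank it against, and nothing to call it stronger or weaker than. Both share the same core and the same furan-bearing side chain; they differ in the amine group at one end and in the fluoro on the ring system of compound 2.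

Compound 3, `CCN(CC)CCNc1nc(NCc2ccco2)c2ccccc2n1`, is the compound still to be measured. Going by the values given here, its single difference from compound 2 is hydrogen in place of fluoro on an aromatic carbon. Among the compounds with values here, because no pair of measured compounds differs in one place, there is no measured step to lean on, and the loss of one fluorine atom is a small change in size. The step from compound 2 to compound 3 is therefore expected to fall within the usual scatter of this assay, with no clear direction: a number 2.5 percentage points lower from compound 2 to compound 3 (within the scatter). Compound 3 is estimated to give about 25% in this assay, with a likely range from 10% to 42%.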

Compound 3, a percentage reported as inhibition, at one concentration (the size of the read-out at that concentration, not a potency): 75.1%
Estimate against measurement, compound 3: 50.1 percentage points below, outside the stated range (above it).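

In this assay, a number 47.6 percentage points higher from compound 2 to compound 3 (beyond the scatter) when one fluoro gives way to hydrogen on an aromatic carbon of the shared core, the carbon that is meta to a fused ring and para to a fused ring. Among the compounds shown here, this is the first measured step, and it shows that this position is sensitive: a change of one heavy atom, with no ring, hydrogen-bond donor, hydrogen-bond acceptor or net charge involved, moves the read-out beyond the usual scatter, and the compound with hydrogen shows the greater inhibition at the concentration tested. Nothing shown here explains how a single atom at this carbon can make so large a difference.

The compounds shown carry only hydrogen or fluoro at this carbon, so it remains open whether a chloro, methyl or methoxy group there would behave like hydrogen, like fluoro or like neither. From the compounds shown here alone, it also remains open whether a step of this size would persist if the diethylamino group at the end of the chain were replaced by a piperidine.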